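The source may hold more compounds than are shown below. What is called first, only, known or untested is meant among the compounds shown, and "the series" means these compounds.

Working notes on the series.

Three compounds of the shared core have been run in a functional assay on MCF7 cells (Homo sapiens) for inhibition, read by CCK-8 assay; a higher number here means a weaker inhibitor, a lower number a stronger inhibitor. Compound 1 `Oc1ccccc1/C=N/c1nnc(SCc2nnc(-c3ccc(Cl)cc3)o2)s1` gives 7550 nM. Compound 2 `Oc1ccccc1/C=N/c1nnc(SCc2nnc(-c3ccccc3Br)o2)s1` gives 9140 nM. Compound 3 `Cc1ccccc1-c1nnc(CSc2nnc(/N=C/c3ccccc3O)s2)o1` gives 9360 nM. The three numbers sit close together: a 1.2-fold higher number from compound 1 to compound 2 (0.08 log units; within the scatter), a 1.2-fold higher number from compound 1 to compound 3 (0.09 log units; within the scatter) and a 1.0-fold higher number from compound 2 to compound 3 (0.01 log units; within the scatter), each within the scatter, so compound 3 cannot be set apart from compound 1 or compound 2 on these data.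

Compound 4 `O=[N+]([O-])c1cccc(-c2nnc(CSc3nnc(/N=C/c4ccccc4O)s3)o2)c1` is not yet measured. It differs from compound 3 as follows: 3-nitrophenyl in place of 2-methylphenyl on an aromatic carbon. Within the data shown here, the steps that bear on it are the swaps of the substituted phenyl on the same ring carbon, namely a 1.2-fold higher number from compound 1 to compound 2 (0.08 log units; within the scatter), a 1.2-fold higher number from compound 1 to compound 3 (0.09 log units; within the scatter) and a 1.0-fold higher number from compound 2 to compound 3 (0.01 log units; within the scatter), none beyond the scatter. Among the measured compounds shown here, a nitro group has not yet been tried in this position, so there is no measured step for it, but every exchange of the aryl group so far has left this assay unchanged within the scatter.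

Compound 4 is therefore expected to give about 9500 nM in this assay, with a range of 5000 nM to 18000 nM, which amounts to an expected step of a 1.0-fold higher number from compound 3 to compound 4 (0.01 log units; within the scatter) and so no change beyond the scatter.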

Compound 4, half-maximal inhibitory concentration: 13900 nM
Compound 4: the middle estimate sits 1.5-fold (0.17 log units) below what was measured; the range from low to high includes it.
By their numbers in this assay, from the lowest: compounds 1, 2, 3 and 4 (each within the scatter of the next).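

In this assay, 3-nitrophenyl on this aromatic carbon of the five-membered ring cannot be set apart from any of the three earlier aryl groups: a 1.5-fold higher number from compound 3 to compound 4 (0.17 log units; within the scatter), a 1.5-fold higher number from compound 2 to compound 4 (0.18 log units; within the scatter) and a 1.8-fold higher number from compound 1 to compound 4 (0.27 log units; within the scatter). The tolerance seen so far with chloro, bromo and methyl on the phenyl therefore extends to nitro, and across these four compounds no exchange of the aryl group moves the number beyond the scatter. No other measurement bears on why these numbers sit so close together.

Going by these compounds, it remains open whether any group on this carbon can move the number beyond the scatter, such as a phenyl bearing an amine or a carboxylic acid, or a longer alkyl chain in place of the phenyl. On these data alone, the shared core is constant throughout, so the effect of changes elsewhere also remains open.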